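Swapping the aryl group on the shared core

A few compounds are considered here, and "the series" means these few. Any claim that something is new, unique, unknown or untested is made for them only; others in the source may bear on it.

Compound 2 `COc1ccc(OC)c(-n2nncc2CN2C(=O)C3(C(C#N)=C(N)Oc4c(N)cc5nc6ccccc6nc5c43)c3ccccc32)c1` was examined in an ADME assay on HUVEC cells (Homo sapiens) for antiproliferative activity, read by MTT assay, with a stated time of 48 h; on this read-out lower numbers stand for stronger inhibition and higher numbers for weaker inhibition. In this assay compound 2 returns only the assay limit of > 50000 nM, not a number. Compound 1 `Cc1ccc(C)c(-n2nncc2CN2C(=O)C3(C(C#N)=C(N)Oc4c(N)cc5nc6ccccc6nc5c43)c3ccccc32)c1` differs from it by a 2,5-dimethylphenyl in place of the 2,5-dimethoxyphenyl on the aromatic nitrogen. In this assay compound 1 likewise stops at the limit > 50000 nM. The step that the two limits leave unreadable from compound 1 to compound 2 therefore cannot be read because both values sit at the same limit (the limit of > 50000 nM in this assay, at which 2 of the 2 values shown sit). The next compound is compound 3 `Cc1cc(C)c(-n2nncc2CN2C(=O)C3(C(C#N)=C(N)Oc4c(N)cc5nc6ccccc6nc5c43)c3ccccc32)c(C)c1`, and the change is: 2,4,6-trimethylphenyl in place of 2,5-dimethoxyphenyl on an aromatic nitrogen. Going by the values given here, the only measured step in this small set, from compound 1 to compound 2, is unreadable, so no size can be taken from it for compound 3. Compound 3 is expected to remain at the assay limit, which means an expected step that the limit leaves unreadable from compound 2 to compound 3. The estimate for compound 3 in this assay is 60000 nM, expected to lie between 30000 nM and 200000 nM.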

Compound 3, half-maximal inhibitory concentration: > 50000 nM
Compound 3 ended at the assay's limit (the forecaster's own chance of this, stated with the estimate: 85%); the middle value lies beyond the limit too.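

Compound 3 stops at the assay limit, as do compound 1 and compound 2, so no step among these three compounds can be read because they all sit at the same limit: the limit of > 50000 nM in this assay, at which 3 of the 3 values shown sit.
In this assay the compounds shown leave open whether any aryl group on the shared core gives a readable value.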